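A few compounds are considered here, and "the series" means these few. Any claim that something is new, unique, unknown or untested is made for them only; others in the source may bear on it.

Measured compounds:
compound 1, `O=S(=O)(NCCNc1nccc(-c2c(-c3cccc(F)c3)nc3sccn23)n1)c1ccc(F)cc1`, gives 9450 nM in a functional assay on A-375 cells (Homo sapiens) for cytotoxicity, read by MTT assay; a higher number here means a weaker inhibitor, a lower number a stronger inhibitor;
compound 2, `O=C(NCCNc1nccc(-c2c(-c3cccc(F)c3)nc3sccn23)n1)c1ccc(Cl)cc1`, gives 2570 nM in this assay.

Compound 2 holds the lowest of these two numbers, with compound 1 higher by a step that lies beyond the usual scatter. The two share one core and differ only in the group carried on an amine nitrogen, and the step of a 3.7-fold lower number from compound 1 to compound 2 (0.57 log units; beyond the scatter) shows that the carbonyl-bearing group went with the lower number.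

Compound 3, `O=S(=O)(NCCNc1nccc(-c2c(-c3cccc(F)c3)nc3sccn23)n1)c1ccccc1`, has not yet been measured. It differs from compound 2 by phenylsulfonyl in place of (4-chlorophenyl)carbonyl on an amine nitrogen. This largely undoes the earlier change: a sulfonyl returns in place of the carbonyl, resembling the group of compound 1 but without the fluorine on its ring. For the measured compounds named here, only one measured step bears on the move, and it was modest. Because a 3.7-fold lower number from compound 1 to compound 2 (0.57 log units; beyond the scatter) ran the other way, a rise of similar size is expected here, although the missing fluorine keeps the comparison loose.

Compound 3 is therefore expected to give about 8000 nM in this assay, with a likely range from 3000 nM to 22000 nM. This expectation amounts to a 3.1-fold higher number from compound 2 to compound 3 (0.49 log units; beyond the scatter).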

Compound 3, half-maximal inhibitory concentration: 11000 nM
Compound 3: middle estimate off by 1.4-fold (0.14 log units), on the low side; the range from low to high includes it.
By their numbers in this assay, from the lowest: compound 2; then compounds 1 and 3 (each within the scatter of the next).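

The step of a 4.3-fold higher number from compound 2 to compound 3 (0.63 log units; beyond the scatter) shows that, in this assay, a second sulfonyl compound also sits well above the carbonyl compound 2, so the earlier gap was not peculiar to compound 1. The step of a 1.2-fold higher number from compound 1 to compound 3 (0.07 log units; within the scatter) shows that fluoro and hydrogen on an aromatic carbon of the sulfonyl-bearing ring cannot be told apart here, so on this pair that fluorine makes no readable difference to the number. No measurement shown offers an explanation for the gap between the sulfonyl compounds and the carbonyl compound.

Compound 2 differs from both sulfonyl compounds in the linking group and also in its ring, which carries chlorine, so these compounds cannot say whether the carbonyl, the chlorine or the two together go with its lower number. A phenylcarbonyl group and a (4-chlorophenyl)sulfonyl group on the same amine nitrogen would separate those two parts, while a longer chain between the two nitrogens remains an open question as well.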